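Ring Size Change in Ghrelin Receptor Antagonist Series

The source may hold more compounds than are shown below. What is called first, only, known or untested is meant among the compounds shown, and "the series" means these compounds.

Measured compounds:
- compound 1, `CN1CCCN(CC(=O)NC2(c3ccc(Cl)c(Cl)c3)C(=O)Nc3cc(Cl)cc(Cl)c32)CC1`: 64 nM
- compound 2, `CCN1CCN(CC(=O)NC2(c3ccc(Cl)cc3)C(=O)Nc3cc(Cl)c(Cl)cc32)CC1`: 110 nM
- compound 3, `CN1CCN(CC(=O)NC2(c3ccc(Cl)cc3)C(=O)Nc3cc(Cl)ccc32)CC1`: 140 nM

Three compounds sharing one oxindole-derived core were tested in an in vitro functional assay on CHO-CREluc cells for antagonist activity at growth hormone secretagogue receptor type 1 (Homo sapiens), read by a luciferase reporter, with a stated time of 4 h; a lower number here means a stronger inhibitor, a higher number a weaker inhibitor. Compound 1 gives the lowest number of the three, at 64 nM. Compound 2 lies closest, with 110 nM, a gap that falls within the scatter of repeat measurements. Compound 3, with 140 nM, stands furthest from compound 1, and that gap lies beyond the scatter. No two of the measured compounds differ in a single place, so no measured step can be read directly.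

The unmeasured compound 4, `CCN1CCN(CC(=O)NC2(c3ccc(Cl)c(Cl)c3)C(=O)Nc3cc(Cl)cc(Cl)c32)CC1`, differs from compound 1 by 4-ethylpiperazin-1-yl in place of 4-methyl-1,4-diazepan-1-yl on a saturated chain carbon bound to a carbonyl carbon. Compounds 2 and 3 carry piperazine-type groups of both kinds and give numbers within a modest span of one another, so only a small step, if any, is expected from compound 1 to compound 4. Compound 4 is estimated at 80 nM in this assay, with a range from 30 nM to 220 nM, corresponding to an expected step of a 1.3-fold higher number from compound 1 to compound 4 (0.10 log units; within the scatter).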

Compound 4, half-maximal inhibitory concentration: 7 nM
The estimate for compound 4 lay 11-fold (1.06 log units) above the measured number; the measured number lies below the stated range.
By their numbers in this assay, from the lowest: compound 4; then compounds 1, 2 and 3 (each within the scatter of the next, the first and the last beyond it).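

In this assay, 4-ethylpiperazin-1-yl in place of 4-methyl-1,4-diazepan-1-yl on a saturated chain carbon bound to a carbonyl carbon gives a 9.1-fold lower number from compound 1 to compound 4 (0.96 log units; beyond the scatter). Going by these compounds alone, this is the first single-place comparison in the set, and it shows that this position responds strongly to a change in which the atom count and the numbers of hydrogen-bond donors and acceptors stay the same, while a seven-membered ring gives way to a six-membered one and methyl gives way to ethyl. No measurement shown here accounts for the size of this step.

As far as these compounds go, whether the step follows the ring size or the ethyl group remains open, and 4-ethyl-1,4-diazepan-1-yl on the core of compound 1 would separate the two. Also open, from the compounds shown here alone, is whether the same change would give a similar step on the cores of compound 2 and compound 3.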